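From 4-phenylphenyl to 4-chlorophenyl in a small series

The compounds below may be only part of what the source reports. "The series", "measured", "known", "first", "only" and "open" are said of these compounds alone.

Of the compounds shown here, three sharing one core have been measured in a functional assay on BGC-823 cells (Homo sapiens) for inhibition, read by MTT assay, with a stated time of 72 h; on this read-out higher numbers stand for weaker inhibition and lower numbers for stronger inhibition. Compound 1 `Cc1ccc(CN2CCc3ncn(COCc4ccccc4)c3/C(=C/c3ccccc3)C2=O)cc1` gives 39100 nM, compound 2 `Cc1cccc(CN2CCc3ncn(COCc4ccccc4)c3/C(=C/c3ccccc3)C2=O)c1` gives 14600 nM and compound 3 `O=C1/C(=C\c2ccccc2)c2c(ncn2COCc2ccccc2)CCN1Cc1ccc(-c2ccccc2)cc1` gives 81000 nM. Compound 3 therefore has the highest number of the three and is the weakest inhibitor in this set. Its nearest neighbour on the numbers is compound 1, and its furthest is compound 2.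

Compound 4 `O=C1/C(=C\c2ccccc2)c2c(ncn2COCc2ccccc2)CCN1Cc1ccc(Cl)cc1` keeps the core of compound 3 and differs in one group: chloro in place of phenyl on an aromatic carbon. This is chloro in place of phenyl on an aromatic carbon, para to a large group.

The most relevant measured change is a 2.1-fold higher number from compound 1 to compound 3 (0.32 log units; beyond the scatter), which also concerns the phenyl on that aromatic carbon, there in place of methyl. The change a 5.5-fold higher number from compound 2 to compound 3 (0.74 log units; beyond the scatter) bears on it less directly, since the group's position differs as well. The change a 2.7-fold lower number from compound 1 to compound 2 (0.43 log units; beyond the scatter) shows that the series responds to more than the loss of the phenyl alone. Going by the values given here, no chloro compound has been measured, so the expectation rests on compound 1 at 39100 nM as the nearest small-group comparison. A modest move to a lower number is expected, with an estimated 2.1-fold lower number from compound 3 to compound 4 (0.33 log units; beyond the scatter). For compound 4 the estimate is 38000 nM, with an expected range of 14000 nM to 85000 nM.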

Compound 4, half-maximal inhibitory concentration: 75700 nM
The estimate for compound 4 lay 2.0-fold (0.30 log units) below the measured number; measured number inside the range.
By their numbers in this assay, from the lowest: compound 2; then compounds 1, 4 and 3 (each within the scatter of the next, the first and the last beyond it).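

In this assay phenyl gives way to chloro at this aromatic carbon, para to a large group, with a 1.1-fold lower number from compound 3 to compound 4 (0.03 log units; within the scatter) and that step lies within the scatter, so replacing a group of 6 heavy atoms with a single chlorine leaves no readable change here. Chloro in place of methyl at the same carbon gives a 1.9-fold higher number from compound 1 to compound 4 (0.29 log units; within the scatter) and also lies within the scatter, which places compound 4 within the scatter of both compound 1 and compound 3 even though the step between those two lies beyond it, so methyl, chloro and phenyl do not form a clear order at this carbon. Going by these compounds alone, the 3-methylphenyl group still stands apart, with a 5.2-fold higher number from compound 2 to compound 4 (0.71 log units; beyond the scatter) and this makes compound 2 the only compound whose steps to all three others lie beyond the scatter.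

From the compounds shown here alone, it remains open whether 3-chlorophenyl would follow 3-methylphenyl, and whether an amine or a carboxylic acid at the carbon para to the large group would shift the number. Nothing at hand accounts for the flat response at this carbon or for the separate standing of compound 2.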